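A few compounds are considered here, and "the series" means these few. Any claim that something is new, unique, unknown or untested is made for them only; others in the source may bear on it.

Compound 1 `Nc1cc(N)c2nc(-c3ccccc3)c(Oc3ccc(Cl)c(Cl)c3)nc2c1` stands as the weaker of the two measured compounds: in a functional assay on TK-10 cells (Homo sapiens) for inhibition, read by sulforhodamine B assay, with a stated time of 48 h (a higher number here means a weaker inhibitor of growth, a lower number a stronger inhibitor of growth), compound 1 gives 63100 nM, whereas compound 2 `COc1cc(CNc2nc3cc(N)cc(N)c3nc2-c2ccccc2)cc(OC)c1OC` gives 17800 nM, a lower number that lies beyond the scatter. Compound 3 `Nc1cc(N)c2nc(-c3ccccc3)c(Oc3ccc(F)cc3)nc2c1` differs from compound 1 in one place, (4-fluorophenyl in place of 3,4-dichlorophenyl on an oxygen on an aromatic ring). Going by the values given here, no measured pair isolates this change, so its effect on growth inhibition is unknown. In this assay only a small step is expected, a 1.3-fold higher number from compound 1 to compound 3 (0.10 log units; within the scatter), leaning toward a higher number. Compound 3 is accordingly estimated at 80000 nM, within a range from 30000 nM to 200000 nM.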

Compound 3, concentration for total growth inhibition: 32400 nM
For compound 3 the middle estimate is 2.5-fold (0.39 log units) above the measured one; measured number inside the range.
By their numbers in this assay, from the lowest: compounds 2, 3 and 1 (each within the scatter of the next, the first and the last beyond it).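

In this assay the exchange of 3,4-dichlorophenyl for 4-fluorophenyl on the oxygen gives a 1.9-fold lower number from compound 1 to compound 3 (0.29 log units; within the scatter) and so leaves growth inhibition indistinguishable. On the core of compound 1, this position therefore accepts both substituted phenyl groups without a change that can be read beyond the scatter. No measurement shown explains this result. The compounds shown leave open whether a carboxylic acid or an amine on this phenyl ring, or a longer alkyl chain in its place on the oxygen, would shift the number.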